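A few compounds are considered here, and "the series" means these few. Any claim that something is new, unique, unknown or untested is made for them only; others in the source may bear on it.

Measured so far in a functional assay on the whole organism with Mus musculus as the target; a higher number here means a larger maximal response, a lower number a smaller maximal response:
- compound 1 `Nc1nc(O)c2c(n1)n(C1OC(CO)[C@@H](O)[C@H]1O)c(=O)n2Cc1ccc(Cl)c(Cl)c1`: 0%
- compound 2 `C=CCn1c(=O)n(C2CN(CCCC)CC(CO)O2)c2nc(N)nc(O)c21`: 52%
- compound 3 `Cn1c(=O)n([C@@H]2O[C@H](CO)[C@H]3OC(C)(C)O[C@H]32)c2nc(N)nc(O)c21`: 17%

Compound 1 stands lowest of the three numbers in this assay. Its nearest neighbour is compound 3, whose maximal response lies higher by a gap beyond the scatter; furthest is compound 2, higher again by a gap beyond the scatter. No pair of these three differs in a single place, so only the bare values can be compared, and nothing about the cause of the gaps can be said.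

Compound 4 `CCn1c(=O)n(C2OC(CO)[C@@H](O)[C@H]2O)c2nc(N)nc(O)c21` has not been measured. It differs from compound 1 by methyl in place of 3,4-dichlorophenyl on a saturated chain carbon bound to an aromatic nitrogen; cut one bond further out, the same difference reads 3,4-dichlorobenzyl to ethyl.

The two compounds that carry a small group on that nitrogen give the higher numbers, compound 3 with 17% and compound 2 with 52%, though both also differ from compound 1 elsewhere. On that basis the step of a number 25 percentage points higher from compound 1 to compound 4 (beyond the scatter) is expected to be upward and beyond the scatter, with wide uncertainty. Compound 4 is estimated at 25% in this assay, with a range from 5% to 50%.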

Compound 4, largest response reached (reported as maximal response), in percent of the reference or control that the assay uses: 82%
Estimate against measurement, compound 4: 57 percentage points below; the whole stated range lies below it.
By their numbers in this assay, from the lowest: compound 1; then compound 3; then compound 2; then compound 4.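

Among the compounds shown here, the change from 3,4-dichlorobenzyl to ethyl, on a saturated chain carbon bound to an aromatic nitrogen, gives the first one-place comparison, and in this assay it reads a number 82 percentage points higher from compound 1 to compound 4 (beyond the scatter) as a large step. This single place therefore has a strong hold on the read-out: with the rest of the structure unchanged, compound 1 at 0% gives no maximal response, while compound 4 reaches 82% once the 3,4-dichlorophenyl part gives way to methyl. No measurement shown here explains why the response follows this change.

The step removes the aromatic ring and both chlorine atoms together, so a plain benzyl or a 4-chlorobenzyl group would be needed to tell which part of the departing group goes with the low number. Going by these compounds, the shape of the response along the alkyl side also stays open, since a single pair cannot show whether a propyl, a butyl or a longer chain on this carbon would hold the response of compound 4 or lose it.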